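Adding a third fluoro to compound 3

This account rests on a few compounds, and the source may have more. Where it says the series, first, only, none or still open, it means among the compounds named here.

Measured compounds:
Compound 1, `Nc1scc(CN2CCN(c3ccccc3C(F)(F)F)CC2)c1C(=O)c1ccc(Cl)cc1`, 0%
Compound 2, `Nc1scc(CN2CCN(c3cccc4ccccc34)CC2)c1C(=O)c1ccc(Cl)cc1`, 8.7%
Compound 3, `Nc1scc(CN2CCN(c3ccc(F)cc3F)CC2)c1C(=O)c1ccc(Cl)cc1`, 0%

All three were run in a functional assay on CHO cells with adenosine receptor A1 (Homo sapiens) as the target, read by cAMP accumulation and immunoassay, with a stated time of 6 min, tested at 0.01 uM; a higher number here means a weaker effect of the compound at the concentration tested, a lower number a stronger effect. Compound 3 stands level with compound 1 at the digits given, and together they are the lowest of the three numbers; the remaining step is a number 8.7 percentage points lower from compound 2 to compound 3 (within the scatter), so none of the three is separated from the others beyond the scatter.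

Compound 4, `Nc1scc(CN2CCN(c3c(F)cc(F)cc3F)CC2)c1C(=O)c1ccc(Cl)cc1`, is the next member. Relative to compound 3 the change is fluoro in place of hydrogen on an aromatic carbon.

Within the data shown here, the steps that bear on it are the aryl exchanges already seen: no change at the digits printed from compound 1 to compound 3 (within the scatter) and a number 8.7 percentage points higher from compound 1 to compound 2 (within the scatter), both within the scatter, and no fluoro-for-hydrogen step has been measured on this core. Nothing in these numbers points to a movement beyond the scatter in this assay. The estimate for compound 4 is therefore 2%, with a range of 0% to 12%, a step of a number 2 percentage points higher from compound 3 to compound 4 (within the scatter) that is expected to lie within the scatter.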

Compound 4, a percentage reported as activity, at one concentration (the size of the read-out at that concentration, not a potency): 4.2%
For compound 4 the middle estimate is 2.2 percentage points below the measured one; the measured number falls inside the stated range.
By their numbers in this assay, from the lowest: compounds 1, 3, 4 and 2 (each within the scatter of the next).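

In this assay, the only fluoro-for-hydrogen step shown on this series, on an aromatic carbon ortho to a large group, is a number 4.2 percentage points higher from compound 3 to compound 4 (within the scatter), so 2,4,6-trifluorophenyl does not separate from 2,4-difluorophenyl at this concentration. The aryl exchanges a number 4.5 percentage points lower from compound 2 to compound 4 (within the scatter) and a number 4.2 percentage points higher from compound 1 to compound 4 (within the scatter) also stay within the scatter, so the four aryl groups on the shared core are not told apart by this read-out. No measurement at hand bears on the reason for this result.

With every step within the scatter at one concentration, these numbers give no potency order for the series. From the compounds shown here alone, it remains open whether a methoxy group, an amine or a carboxylic acid on this aromatic ring would move the number beyond the scatter.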